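Carbamate series: methyl placement on the aryl ring

The source may report more compounds than this note shows. Statements on the series, on what has been measured and on what is new or still open speak of the compounds shown alone.

Among the compounds with values here, compound 3 `COc1ccc(N2CCN(CCC(OC(N)=O)c3ccc(C)cc3C)CC2)cc1` heads the three measured members in a functional assay on the whole organism for inhibition, with Mus musculus as the target, in the writhing test, with a stated time of 1 h, at a dose of 10 mg/kg by the oral route (a higher number here means more inhibition at the dose given (going by the name of the read-out), a lower number less inhibition), with 62%. Compound 2 `COc1ccc(N2CCN(CCC(OC(N)=O)c3ccc(Cl)c(Cl)c3)CC2)cc1` gives 61% in this assay, and the step of a number 1 percentage points higher from compound 2 to compound 3 (within the scatter) is within the scatter, so the two cannot be ordered. Compound 1 `COc1ccc(N2CCN(CCC(OC(N)=O)c3ccc(Cl)cc3)CC2)cc1` gives 51% in this assay, and the step of a number 11 percentage points higher from compound 1 to compound 3 (beyond the scatter) is beyond the scatter; the step of a number 10 percentage points higher from compound 1 to compound 2 (within the scatter) is within it.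

Compound 4 `COc1ccc(N2CCN(CCC(OC(N)=O)c3ccc(C)c(C)c3)CC2)cc1` differs from compound 3 only in the arrangement of the same atoms: 3,4-dimethylphenyl in place of 2,4-dimethylphenyl on a saturated chain carbon bound to an oxygen next to a carbonyl group and a saturated chain carbon. Within the data shown here, no measured step moves a substituent around the same ring in this way. The closest comparison is the step from compound 2 to compound 3, where an exchange of the whole aryl group gave a number 1 percentage points higher from compound 2 to compound 3 (within the scatter), and the step from compound 1 to compound 2, where a second ring substituent gave a number 10 percentage points higher from compound 1 to compound 2 (within the scatter). Both are within the scatter, so no step beyond the scatter is expected in this assay from compound 3 to compound 4; the estimated step is a number 2 percentage points lower from compound 3 to compound 4 (within the scatter). For compound 4 the expected value in this assay is 60%, with a range of 48% to 72%.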

Compound 4, a percentage reported as inhibition, in the whole organism at one dose (the size of the read-out at that dose, not a potency): 58%
For compound 4 the middle estimate is 2 percentage points above the measured one, and the stated range covers the measured number.
By their numbers in this assay, from the lowest: compounds 1, 4, 2 and 3 (each within the scatter of the next, the first and the last beyond it).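

In this assay, within the data shown here, exchanging 2,4-dimethylphenyl for 3,4-dimethylphenyl on a saturated chain carbon bound to an oxygen next to a carbonyl group and a saturated chain carbon gives a number 4 percentage points lower from compound 3 to compound 4 (within the scatter), the first reading of a change that rearranges the same atoms, and it shows no difference that can be separated from the scatter. Among these compounds, the exchange of 3,4-dichlorophenyl for 3,4-dimethylphenyl gives a number 3 percentage points lower from compound 2 to compound 4 (within the scatter) and that of 4-chlorophenyl for 3,4-dimethylphenyl gives a number 7 percentage points higher from compound 1 to compound 4 (within the scatter), so the two methyl groups in this arrangement cannot be told apart from either chlorinated aryl group, and a number 11 percentage points higher from compound 1 to compound 3 (beyond the scatter) remains the only step beyond the scatter. No measurement at hand accounts for these aryl groups reading alike.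

Open, from the compounds shown here alone, is whether 2,4-dichlorophenyl would read like 2,4-dimethylphenyl, and whether a methoxy or trifluoromethyl group on the aryl ring would take the number outside the present band. Also open is what a longer chain between the carbamate-bearing carbon and the shared core would do, and a single-dose read-out cannot give the potency of any of these compounds.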